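Adding a butyl chain to the phenyl of compound 1

The source may report more compounds than this note shows. Statements on the series, on what has been measured and on what is new or still open speak of the compounds shown alone.

Compound 1, `O=C1C2=C(C(=O)c3ncccc31)C1(CS2)NC(=O)N(c2ccccc2)C1=O`, gives 21 nM in a functional assay on ACHN cells (Homo sapiens) for antiproliferative activity, read by MTT assay, with a stated time of 96 h; a lower number here means a stronger inhibitor, a higher number a weaker inhibitor.
Compound 2, `O=C1NN(c2ccc([N+](=O)[O-])cc2)C(=O)C2(CSC3=C2C(=O)c2ncccc2C3=O)N1`, gives 650 nM in this assay.
Compound 3, `O=C1NN(c2ccc(Cl)cc2)C(=O)C2(CSC3=C2C(=O)c2ncccc2C3=O)N1`, gives 360 nM in this assay.

Compound 1 has the lowest of the three numbers; compound 3 stands a sizeable gap above it, and compound 2 further still, both gaps beyond the scatter, so compound 1 is the strongest inhibitor here. Within the data shown here, the only step between the measured compounds, a 1.8-fold lower number from compound 2 to compound 3 (0.26 log units; within the scatter), concerns a different pair within the same shared core and lies within the scatter.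

Compound 4, `CCCCc1ccc(N2C(=O)NC3(CSC4=C3C(=O)c3ncccc3C4=O)C2=O)cc1`, differs from compound 1 by butyl in place of hydrogen on an aromatic carbon. Among the measured compounds shown here, no measured step touches this change: the one available step swaps chloro for nitro, not hydrogen for butyl, and sits in a related but not identical ring system. The data therefore give no reason to expect a move beyond the scatter in either direction. Compound 4 is estimated at 30 nM, with a range of 8 nM to 110 nM, which means an expected step of a 1.4-fold higher number from compound 1 to compound 4 (0.15 log units; within the scatter).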

Compound 4, half-maximal inhibitory concentration: 50 nM
For compound 4 the middle estimate is 1.7-fold (0.22 log units) below the measured one; the range from low to high includes it.
By their numbers in this assay, from the lowest: compound 1; then compound 4; then compounds 3 and 2 (each within the scatter of the next).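

In this assay, butyl in place of hydrogen on the phenyl ring, para to a large group, gives a 2.4-fold higher number from compound 1 to compound 4 (0.38 log units; beyond the scatter), a modest step beyond the scatter. The earlier compounds shown here held no step at this position on the core of compound 1, and this first reading shows that the position accepts a chain of this size at a modest cost, with compound 4 still at 50 nM in this assay and no collapse of the activity. Nothing shown here explains why the number rises with this change.

With butyl as the only group shown at this carbon, it remains open whether methyl, a longer chain, an amine or a carboxylic acid there would lower or raise the number. Chloro and nitro appear only on compounds 3 and 2, whose core differs, so their effect on the core of compound 1 also remains open.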